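The compounds below may be only part of what the source reports. "The series", "measured", "known", "first", "only" and "open" are said of these compounds alone.

Working notes on the series. In a physicochemical assay for solubility, read by spectrophotometry, in phosphate buffer, with a stated time of 18 h, at pH 7.4 (a lower number here means a less soluble compound, a higher number a more soluble compound), compound 1 `CCc1ccc(-c2nc3c(c(C)nn3-c3ccccc3)c(-c3ccccc3O)c2C#N)cc1` gives 3100 nM. Compound 2 `CCc1ccc(-c2nc3c(c(C)nn3-c3ccccc3)c(-c3ccccc3Br)c2C#N)cc1`, with bromo in place of hydroxy on an aromatic carbon, gives 1500 nM. Compound 3 `CCc1ccc(-c2nc3c(c(C)nn3-c3ccccc3)c(-c3ccccc3F)c2C#N)cc1`, with fluoro in place of hydroxy on an aromatic carbon, gives 1700 nM. The two steps away from the hydroxy compound are a 2.1-fold lower number from compound 1 to compound 2 (0.32 log units; beyond the scatter) and a 1.8-fold lower number from compound 1 to compound 3 (0.26 log units; within the scatter). Compound 1 therefore stands clear of compound 2 but not of compound 3, and the two halogen compounds are separated by a 1.1-fold higher number from compound 2 to compound 3 (0.05 log units; within the scatter).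

Compound 4 `Cc1nn(-c2ccccc2)c2nc(-c3ccc(C(C)C)cc3)c(C#N)c(-c3ccccc3O)c12` keeps the hydroxy group and differs elsewhere, as ethyl to isopropyl, or 4-ethylphenyl to 4-isopropylphenyl: methyl in place of hydrogen on a saturated chain carbon bound to an aromatic carbon and a saturated chain carbon. This is methyl in place of hydrogen on a saturated chain carbon bound to an aromatic carbon and a saturated chain carbon. Going by the values given here, none of the measured steps touches this group, since all three exchange substituents on an aromatic carbon. Among the compounds with values here, they offer only a rough scale, and the series holds no direct example of this change. No step beyond the scatter is therefore expected in this assay. The estimated change is a 1.2-fold lower number from compound 1 to compound 4 (0.08 log units; within the scatter). The expected value for compound 4 is 2600 nM, with an estimated range from 1300 nM to 4800 nM.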

Compound 4, solubility: 9800 nM
The estimate for compound 4 lay 3.8-fold (0.58 log units) below the measured number; measured number above the stated range.
By their numbers in this assay, from the lowest: compounds 2, 3 and 1 (each within the scatter of the next, the first and the last beyond it); then compound 4.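

In this assay the saturated chain carbon bound to an aromatic carbon and a saturated chain carbon turns out to be a place where the read-out responds to a single added methyl, with the hydroxy group kept: the step is a 3.2-fold higher number from compound 1 to compound 4 (0.50 log units; beyond the scatter) and stands beyond the scatter. Going by these compounds alone, the earlier steps all exchanged substituents on an aromatic carbon and, starting from compound 1, led only to lower numbers, so this is the first step from compound 1 toward a higher number and the first evidence on the 4-ethylphenyl side of the molecule. Nothing measured for these compounds accounts for the direction or size of this step.

Going by these compounds, this place is represented only by the 4-ethylphenyl and 4-isopropylphenyl groups, so it remains open whether a 4-tert-butylphenyl or 4-cyclopropylphenyl group would carry the number further or reverse it. It also remains open whether the same change from ethyl to isopropyl would give a step of similar size in the bromo and fluoro compounds, as compound 2 and compound 3 are shown only with the 4-ethylphenyl group.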